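Aryl replacement on the saturated ring carbon of the shared core

The source may report more compounds than this note shows. Statements on the series, on what has been measured and on what is new or still open speak of the compounds shown alone.

Measured compounds:
- compound 1 `Cc1ccc(C2C(C#N)=C(N)N(c3ccc(S(N)(=O)=O)cc3)C3=C2C(=O)CCC3)cc1`: 100%
- compound 2 `N#CC1=C(N)N(c2ccc(S(N)(=O)=O)cc2)C2=C(C(=O)CCC2)C1/C=C/c1ccccc1`: 45%
- compound 3 `COc1cc(CC2C(C#N)=C(N)N(c3ccc(S(N)(=O)=O)cc3)C3=C2C(=O)CCC3)ccc1O`: 100%

All three were read in a functional assay on Ehrlich cells (Mus musculus) for antiproliferative activity, read by trypan blue exclusion, with a stated time of 2 h, tested at 100 ug/mL; a lower number here means a weaker effect, a higher number a stronger effect of the compound at the concentration tested. Compound 3 stands level with compound 1 at the digits printed, the two together being the highest of the three numbers; compound 2 is the furthest from it, as a number 55 percentage points higher from compound 2 to compound 3 (beyond the scatter) shows. The step of no change at the digits printed from compound 1 to compound 3 (within the scatter) is within the scatter, whereas a number 55 percentage points lower from compound 1 to compound 2 (beyond the scatter) is large.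

Compound 4 `N#CC1=C(N)N(c2ccc(S(N)(=O)=O)cc2)C2=C(C(=O)CCC2)C1c1ccc(Cl)cc1Cl` is not yet measured. It differs from compound 3 as follows: 2,4-dichlorophenyl in place of 4-hydroxy-3-methoxybenzyl on a saturated ring carbon.

Among the compounds with values here, the steps that bear on this are no change at the digits printed from compound 1 to compound 3 (within the scatter), which shows that exchanging one aromatic substituent for another at this carbon left the number unchanged, and a number 55 percentage points higher from compound 2 to compound 3 (beyond the scatter), which shows that only the 2-phenylethenyl substituent gave a lower number. Compound 4 carries an aromatic ring directly on the saturated ring carbon, as compound 1 does, so no step beyond the scatter is expected from compound 3. The expected step is a number 8 percentage points lower from compound 3 to compound 4 (within the scatter). Compound 4 is therefore estimated at 92%, with a range from 60% to 100%.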

Compound 4, a percentage reported as activity, at one concentration (the size of the read-out at that concentration, not a potency): 95%
For compound 4 the middle estimate is 3 percentage points below the measured one; measured number inside the range.
By their numbers in this assay, from the lowest: compound 2; then compounds 4, 1 and 3 (each within the scatter of the next).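

In this assay the change to 2,4-dichlorophenyl, which carries 0 hydrogen-bond donors and 0 hydrogen-bond acceptors, gives a number 5 percentage points lower from compound 3 to compound 4 (within the scatter) and, against 4-methylphenyl, a number 5 percentage points lower from compound 1 to compound 4 (within the scatter), so the position accepts a ring bearing chlorine as well as the methyl-bearing and the hydroxy- and methoxy-bearing rings. With a number 50 percentage points higher from compound 2 to compound 4 (beyond the scatter), compound 2, with its 2-phenylethenyl group, remains the only one of the four set apart from the others. Nothing available here accounts for that separation.

As far as these compounds go, whether the position keeps this level with no aromatic ring at all, as with a plain butyl chain, or with an amine or a carboxylic acid on the ring, remains open. From the compounds shown here alone, each compound was read at one concentration, so whether compounds 1, 3 and 4 would show a stronger or weaker effect than one another at any other concentration also remains open.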